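The source may hold more compounds than are shown below. What is called first, only, known or untested is meant among the compounds shown, and "the series" means these compounds.

Measured so far in a functional assay on SGC-7901 cells (Homo sapiens) for antiproliferative activity, read by sulforhodamine B assay, with a stated time of 72 h; a lower number here means a stronger inhibitor, a higher number a weaker inhibitor:
compound 1 `COc1ccc(C)cc1NC(=S)N/N=C/c1ccc2ccccc2n1`: > 100000 nM
compound 2 `Cc1cccc(NC(=S)N/N=C/c2ccc3ccccc3n2)c1`: > 100000 nM
compound 3 `S=C(N/N=C/c1ccc2ccccc2n1)Nc1ccccc1`: 26500 nM

The value given for compound 1 is a limit of this assay, not a number. The value given for compound 2 is likewise a limit. Only compound 3 gives a number in this assay, 26500 nM; the two other values sit at the limit of > 100000 nM in this assay, at which 2 of the 3 values shown sit.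

The step from compound 2 to compound 3 is an at least 3.7-fold lower number from compound 2 to compound 3 (0.57 log units; beyond the scatter), the change being (hydrogen in place of methyl on an aromatic carbon). The step from compound 2 to compound 1 is a step that the two limits leave unreadable from compound 2 to compound 1, the change being (methoxy in place of hydrogen on an aromatic carbon).

Not yet measured is compound 4 `COc1ccc(NC(=S)N/N=C/c2ccc3ccccc3n2)cc1`. It differs from compound 3 by methoxy in place of hydrogen on an aromatic carbon. This is the same kind of change as that from compound 2 to compound 1, but the place is not the same: there the methoxy enters ortho to a large group and para to a methyl group, here it enters para to a large group. Since that earlier step is not readable, the expected step from compound 3 to compound 4 in this assay rests only on the number for compound 3 and is estimated to be a 1.3-fold higher number from compound 3 to compound 4 (0.12 log units; within the scatter). For compound 4 the estimated value in this assay is 35000 nM, with a wide range from 9000 nM to 130000 nM, and a fair chance that only a limit is reported.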

Compound 4, half-maximal inhibitory concentration: 89600 nM
For compound 4 the middle estimate is 2.6-fold (0.41 log units) below the measured one; measured number inside the range.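

In this assay, methoxy in place of hydrogen, para to a large group, gives a 3.4-fold higher number from compound 3 to compound 4 (0.53 log units; beyond the scatter), so on this core the change goes with a higher number. The same kind of change on the core of compound 2 cannot be read, because compound 2 and compound 1 each stand at a limit of the assay rather than at a number: the limit of > 100000 nM in this assay, at which 2 of the 4 values shown sit. The swap to 4-methoxyphenyl from 3-methylphenyl gives an at least 1.1-fold lower number from compound 2 to compound 4 (0.04 log units; that floor lies within the scatter), a floor that separates nothing, so one readable pair shows the effect on a single core and does not show whether it carries to another.

Open, going by these compounds, is whether any group on this phenyl ring gives a lower number than compound 3 at 26500 nM in this assay. A carboxylic acid, an amine or a longer chain such as ethoxy in the same place would test this.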